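Notes on the amide substituent step from compound 3 to compound 4

The source may report more compounds than this note shows. Statements on the series, on what has been measured and on what is new or still open speak of the compounds shown alone.

Measured in a functional assay on MDA-MB-231 cells (Homo sapiens) for inhibition, read by MTT assay, with a stated time of 48 h; on this read-out higher numbers stand for weaker inhibition and lower numbers for stronger inhibition:
Compound 1 `Cn1c(/C=C2\SC(=O)N(CC(=O)Nc3cc(C(C)(C)C)on3)C2=O)nc2ccccc21` gives 33800 nM.
Compound 2 `CCn1c(/C=C2\SC(=O)N(CC(=O)N3CCOCC3)C2=O)nc2ccccc21` gives > 50000 nM, a limit of the assay.
Compound 3 `CCn1c(/C=C2\SC(=O)N(CC(=O)Nc3cc(C(C)(C)C)on3)C2=O)nc2ccccc21` gives > 50000 nM, also a limit of the assay.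

Compound 3 therefore stands at the limit of > 50000 nM in this assay, at which 2 of the 3 values shown sit, and has no number of its own. Compound 4 `CCn1c(/C=C2\SC(=O)N(CC(=O)N3CCCCC3)C2=O)nc2ccccc21` is not yet measured and differs from compound 3 in one place: piperidin-1-yl in place of (5-(tert-butyl)-1,2-oxazol-3-yl)amino on a carbonyl carbon. Going by the values given here, two measured steps touch compound 3. The step of an at least 1.4-fold higher number from compound 1 to compound 3 (0.17 log units; that floor lies within the scatter) concerns the saturated chain carbon bound to an aromatic nitrogen, not the carbonyl carbon, and its floor lies within the scatter. The step that the two limits leave unreadable from compound 2 to compound 3 does concern the carbonyl carbon, morpholin-4-yl against (5-(tert-butyl)-1,2-oxazol-3-yl)amino, but both of its ends sit at the limit, so its size cannot be read. Compound 4 carries piperidin-1-yl, a six-membered non-aromatic ring as morpholin-4-yl in compound 2 is, and compound 2 sits at the limit. Among the compounds with values here, no measured step gives a direction for the change. Compound 4 is therefore expected to sit at the limit as well, with a step that the limit leaves unreadable from compound 3 to compound 4 that is not expected to be readable. Compound 4 is estimated at 70000 nM, within 25000 nM to 200000 nM.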

Compound 4, half-maximal inhibitory concentration: > 50000 nM
Compound 4 was reported as a limit (the forecaster's own chance of this, stated with the estimate: 85%); the middle value lies beyond the limit too.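

In this assay compound 4 gives > 50000 nM, a limit of the assay. Going by these compounds alone, compound 2 and compound 3 also stand at limits, so no step to compound 4 from either can be read. The compounds shown leave open how morpholin-4-yl, piperidin-1-yl and (5-(tert-butyl)-1,2-oxazol-3-yl)amino on the carbonyl carbon rank against one another.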